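The source may report more compounds than this note shows. Statements on the series, on what has been measured and on what is new or still open speak of the compounds shown alone.

Three compounds have been measured in a functional assay on THP-1 cells (Homo sapiens) for inhibition; on this read-out higher numbers stand for weaker inhibition and lower numbers for stronger inhibition:

compound 1 `O=C1NC(=O)/C(=C/c2ccc(C(=O)NC[C@@H]3C[C@@H](OCc4ccccc4-c4ccccc4)CN3C(=O)c3ccccc3C(=O)c3ccc(F)cc3F)cc2)S1` gives 230 nM.
compound 2 `O=C1NC(=O)/C(=C/c2ccc(C(=O)NC[C@@H]3C[C@@H](OCc4ccccc4-c4ccccc4)CN3C(=O)c3ccccc3C(=O)c3ccc(F)cc3)cc2)S1` gives 320 nM.
compound 3 `CC(C)Cc1cccc(Br)c1O[C@@H]1C[C@@H](CNC(=O)c2ccc(/C=C3\SC(=O)NC3=O)cc2)N(C(=O)c2ccccc2C(=O)c2ccc(F)cc2)C1` gives 300 nM.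

Compound 2 stands at the top end of these three numbers, but its gaps to compound 3 and to compound 1 are both within the usual scatter of this kind of measurement, so no real ordering among the three can be claimed. Among the compounds with values here, the only measured step that changes a single place, a 1.4-fold higher number from compound 1 to compound 2 (0.14 log units; within the scatter), removed a fluoro from an aromatic ring and stayed within the scatter.

Compound 4 `O=C1NC(=O)/C(=C/c2ccc(C(=O)NC[C@@H]3C[C@@H](OCc4ccccc4-c4ccccc4)CN3C(=O)c3ccccc3C(=O)c3ccccc3)cc2)S1` differs from compound 2 in just the same manner: hydrogen in place of fluoro on an aromatic carbon. Within the data shown here, the step from compound 1 to compound 2 is the one measured step that bears on this change, and it was within the scatter. A like outcome is therefore expected for compound 4 in this assay, namely a step of a 1.1-fold higher number from compound 2 to compound 4 (0.04 log units; within the scatter) that does not go beyond the scatter in either direction. Compound 4 is estimated at 350 nM, within a range from 150 nM to 800 nM.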

Compound 4, half-maximal inhibitory concentration: 670 nM
Compound 4: the middle estimate sits 1.9-fold (0.28 log units) below what was measured, and the stated range covers the measured number.
By their numbers in this assay, from the lowest: compounds 1, 3 and 2 (each within the scatter of the next); then compound 4.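

In this assay, going from the 4-fluorophenyl to the plain phenyl gives a 2.1-fold higher number from compound 2 to compound 4 (0.32 log units; beyond the scatter) and this lies modestly beyond the scatter. The fluoro on this aromatic carbon, para to a large group, therefore counts here, unlike the fluoro removed in the earlier step of a 1.4-fold higher number from compound 1 to compound 2 (0.14 log units; within the scatter) that stayed within it. Phenyl in place of 2,4-difluorophenyl gives a 2.9-fold higher number from compound 1 to compound 4 (0.46 log units; beyond the scatter) and this too lies beyond the scatter, so compound 4, with no fluoro on this ring, inhibits more weakly than compound 1 and compound 2, which carry one or two.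

On these data alone, whether a chloro, a methoxy or an amine at this place would match the fluoro stays open, as does whether the same change would act alike on the core of compound 3. No measurement at hand says why removing this fluoro weakens inhibition.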